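The source may hold more compounds than are shown below. What is called first, only, known or untested is meant among the compounds shown, and "the series" means these compounds.

Working notes on the series. Among the compounds with values here, in a functional assay on B16-F10 cells (Mus musculus) for cytotoxicity, read by MTT assay, with a stated time of 48 h (on this read-out higher numbers stand for weaker inhibition and lower numbers for stronger inhibition), compound 2 `CCc1ccc(NC(=O)N(Cc2cc(OC)c(OC)c(OC)c2)n2cnnc2)cc1` gives 24700 nM, the only number in the set so far. Compound 1 `COc1ccc(CN(C(=O)Nc2ccc(C#N)cc2)n2cnnc2)cc1OC` reaches only a limit of this assay, > 50000 nM. That limit appears as the limit of > 50000 nM in this assay, at which 1 of the 2 values shown sits, in the evidence at hand. Compound 3 `CCc1ccc(NC(=O)N(Cc2ccc(OC)c(OC)c2)n2cnnc2)cc1` remains to be measured in this assay. The change from compound 2 to compound 3 is hydrogen in place of methoxy on an aromatic carbon, ortho to a methoxy group and meta to a large group and to a methoxy group. Within the data shown here, no measured step in the set isolates this change, so no direction is fixed by the data. The expected step is one no larger than the usual scatter, a 1.2-fold higher number from compound 2 to compound 3 (0.08 log units; within the scatter), with at most a slight lean toward weaker inhibition. Compound 3 is therefore estimated at 30000 nM, with a range of 12000 nM to 60000 nM.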

Compound 3, half-maximal inhibitory concentration: 22900 nM
Compound 3: middle estimate off by 1.3-fold (0.12 log units), on the high side; measured number inside the range.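

Within the data shown here, the first measured step at this position is a 1.1-fold lower number from compound 2 to compound 3 (0.03 log units; within the scatter), so in this assay hydrogen in place of methoxy on an aromatic carbon, ortho to a methoxy group, does not separate these two compounds. Among these compounds, a second change, ethyl in place of cyano on an aromatic carbon, gives an at least 2.1-fold lower number from compound 1 to compound 3 (0.33 log units; beyond the scatter), the first step in the set that lies beyond the scatter. Compound 1 gives > 50000 nM, which is a limit of the assay and not a number.

The compounds shown leave open whether an amine or a hydroxy group in place of that methoxy would move the number at all. They also leave open whether a longer chain in place of ethyl would give a lower number than compound 3 gives.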